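Piperazine to Piperidine on the Fused Core

The compounds below may be only part of what the source reports. "The series", "measured", "known", "first", "only" and "open" are said of these compounds alone.

Compound 1 `N#Cc1cc2sc3cc(N4CCNCC4)ccc3c2n2c1nc1ccccc12`: 2.75
Compound 2 `N#Cc1c(N2CCNCC2)c2sc3cc(N4CCNCC4)ccc3c2n2c1nc1ccccc12`: 1.89

In a physicochemical assay for lipophilicity, read by HPLC, at pH 7.4 (on this read-out higher numbers stand for higher lipophilicity and lower numbers for lower lipophilicity), compound 1 stands highest of the two numbers, with compound 2 nearest at a number 0.86 log units lower from compound 1 to compound 2 (beyond the scatter). Compound 3 `N#Cc1cc2sc3cc(N4CCCCC4)ccc3c2n2c1nc1ccccc12` differs from compound 1 by piperidin-1-yl in place of piperazin-1-yl on an aromatic carbon. For the measured compounds named here, the only step that bears on it is a number 0.86 log units lower from compound 1 to compound 2 (beyond the scatter), where piperazin-1-yl entered; here piperazin-1-yl leaves instead, so a rise beyond the scatter is expected, about a number 0.75 log units higher from compound 1 to compound 3 (beyond the scatter). Compound 3 is therefore estimated at 3.5, within 3 to 4.1.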

Compound 3, distribution coefficient: 8.5
The estimate for compound 3 lay 5.00 log units below the measured number; measured number outside the range, above it.
By their numbers in this assay, from the lowest: compound 2; then compound 1; then compound 3.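

The change of piperazin-1-yl to piperidin-1-yl on this aromatic carbon gives a large step in this assay, a number 5.75 log units higher from compound 1 to compound 3 (beyond the scatter). Its size could not be read from the entry of piperazin-1-yl elsewhere on the shared core, a number 0.86 log units lower from compound 1 to compound 2 (beyond the scatter). No measurement at hand accounts for a step of this size.

Going by these compounds, whether morpholin-4-yl or an open-chain amine on this carbon would read nearer compound 1 or compound 3 stays open. Also open, on these data alone, is whether the step holds on the core of compound 2.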